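Removing One Methyl from Compound 2

This account rests on a few compounds, and the source may have more. Where it says the series, first, only, none or still open, it means among the compounds named here.

Of the compounds shown here, three sharing one core have been measured in a functional assay on LOX IMVI cells (Homo sapiens) for cytotoxicity, read by MTT assay, with a stated time of 24 h; a higher number here means a weaker inhibitor, a lower number a stronger inhibitor. Compound 1 `COc1cc(-c2nc(-c3ccccc3)[nH]c2-c2ccnc(NCCCNS(=O)(=O)c3ccc(F)cc3)n2)ccc1Cl` gives 4530 nM, compound 2 `COc1cc(-c2nc(-c3ccccc3)[nH]c2-c2ccnc(NCCCNS(=O)(=O)c3ccc(C)cc3)n2)ccc1Cl` gives 18600 nM, and compound 3 `COc1ccc(S(=O)(=O)NCCCNc2nccc(-c3[nH]c(-c4ccccc4)nc3-c3ccc(Cl)c(OC)c3)n2)cc1` gives 1800 nM. Compound 2 has the highest number of the three, which makes it the weakest inhibitor among them.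

Compound 4 `Cc1ccc(S(=O)(=O)NCCCNc2nccc(-c3[nH]c(-c4ccccc4)nc3-c3ccc(Cl)c(O)c3)n2)cc1` differs from compound 2 by one small edit, hydrogen in place of methyl on an oxygen on an aromatic ring, turning methoxy into hydroxy. For the measured compounds named here, no measured step makes this change, and all three measured compounds still carry that methoxy. The measured steps swap groups on an aromatic carbon instead, so they bear on it only indirectly. They show how far one small swap can move the number in this series: a 4.1-fold higher number from compound 1 to compound 2 (0.61 log units; beyond the scatter) and a 2.5-fold lower number from compound 1 to compound 3 (0.40 log units; beyond the scatter) are modest, while a 10-fold lower number from compound 2 to compound 3 (1.01 log units; beyond the scatter) is large.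

Direction is therefore a weak judgement, resting on compound 2 sitting at the top of the measured range at 18600 nM. A modest move towards a lower number in this assay is expected, and the expected step is a 2.3-fold lower number from compound 2 to compound 4 (0.37 log units; beyond the scatter). For compound 4 the estimated value is 8000 nM, with an expected range from 2500 nM to 25000 nM.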

Compound 4, half-maximal inhibitory concentration: 6020 nM
Compound 4: middle estimate off by 1.3-fold (0.12 log units), on the high side; low and high end bracket the measured number.
By their numbers in this assay, from the lowest: compound 3; then compounds 1 and 4 (each within the scatter of the next); then compound 2.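

In this assay, turning methoxy into hydroxy on the 4-chloro-3-methoxyphenyl group gives a 3.1-fold lower number from compound 2 to compound 4 (0.49 log units; beyond the scatter), a modest step but one beyond the scatter. For the compounds shown here, the earlier compounds all kept this methoxy and changed only a group on an aromatic carbon elsewhere, so this is the first sign that the number also responds to a change at this oxygen, and that removing a single carbon is enough to move it. Nothing available here accounts for the direction or size of this step.

Methoxy and hydroxy are the only two forms of this position shown, so it remains open how the number would respond to a longer chain on the oxygen, such as ethoxy, or to an amine in place of the hydroxy. The change has also been read only in compounds carrying the methyl group of compound 2, which leaves open whether the same step would appear alongside the fluoro of compound 1 or the methoxy of compound 3.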